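The compounds below may be only part of what the source reports. "The series", "measured", "known", "first", "only" and "open" are said of these compounds alone.

Compound 1 `CC(C)n1nc(-c2ccnc3[nH]c(C4CCN(CC(=O)N(C)C)CC4)cc23)ccc1=O` holds the only numerical result in an ADME assay on microsomes from liver (Homo sapiens) for metabolic stability (on this read-out lower numbers stand for slow clearance and higher numbers for fast clearance), where compound 1 gives 13 uL/min. In this assay compound 2 `CC(C)n1cc(-c2ccnc3[nH]c(C4CCNCC4)cc23)ccc1=O` reports < 3 uL/min, which is a limit of the assay and not a number. Compound 3 `CCn1cc(-c2ccnc3[nH]c(C4CCN(CC(=O)N(C)C)CC4)cc23)ccc1=O` differs from compound 1 by a group of 9 heavy atoms (7 carbon, 1 nitrogen, 1 oxygen; one six-membered aromatic ring with 1 hetero atom) in place of a group of 10 heavy atoms (7 carbon, 2 nitrogen, 1 oxygen; one six-membered aromatic ring with 2 hetero atoms), on an aromatic carbon. Among the compounds with values here, no measured pair in this set reproduces that change, so nothing beyond the usual scatter is expected in this assay, and the estimated step is a 1.3-fold lower number from compound 1 to compound 3 (0.11 log units; within the scatter). In this assay compound 3 is therefore expected to give about 10 uL/min, with a likely range from 4 uL/min to 25 uL/min.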

Compound 3, intrinsic clearance in a liver preparation (reported as CLH), per the amount of preparation that the assay uses in the Homo sapiens assay: < 3 uL/min
Compound 3 ended at the assay's limit; the forecaster's own chance of this, stated with the estimate: 15%; middle value at least 3.3-fold (0.52 log units) from the limit.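

The new comparison shows that this aromatic carbon, opposite the ring nitrogen, is sensitive to the group it carries: exchanging the group with two ring hetero atoms for the one with a single ring hetero atom gives, in the Homo sapiens assay, an at least 4.3-fold lower number from compound 1 to compound 3 (0.63 log units; beyond the scatter). In a physicochemical assay for solubility, in phosphate buffer, at pH 7.4 (a higher number here means a more soluble compound, a lower number a less soluble compound), compound 1 gives 11000 nM. In the physicochemical assay compound 3 gives > 1000000 nM, which is a limit of the assay and not a number.

Which part of the exchanged group carries these steps stays open. So does how a longer chain or a carboxylic acid on this aromatic carbon would read in either assay.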